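A Fluorobenzyl Swap Awaiting Its Stability Reading

The source may report more compounds than this note shows. Statements on the series, on what has been measured and on what is new or still open speak of the compounds shown alone.

Three compounds with closely related structures were taken into an ADME assay on microsomes from liver (Homo sapiens) for metabolic stability, with a stated time of 30 min; a higher number here means that more of the compound is left, a lower number that less of the compound is left. Among the compounds with values here, there, compound 1 (`CC(C)[C@@H](CO)n1cc(C(=O)O)c(=O)c2cc(Cc3cccc(Cl)c3F)ncc21`) gives 100%, the only number in the set. Compound 2 (`COc1nc2c(cc1Cc1cccc(Cl)c1F)c(=O)c(C(=O)O)cn2[C@@H](C)CO`) is recorded as "not determined" (no result reported). Compound 3 (`COc1nc2c(cc1Nc1cccc(Cl)c1F)c(=O)c(C(=O)O)cn2[C@H](CO)C(C)C`) fares no better, also entered as "not determined" (no result reported), so it offers no single number as a starting point.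

Compound 4 (`COc1nc2c(cc1NCc1ccccc1F)c(=O)c(C(=O)O)cn2[C@H](CO)C(C)C`) differs from compound 3 in one place: 2-fluorobenzyl in place of 3-chloro-2-fluorophenyl on a nitrogen on an aromatic ring. Put another way, (3-chloro-2-fluorophenyl)amino becomes (2-fluorobenzyl)amino. Within the data shown here, with no measured step to draw on, the effect of this change in this assay cannot be read from the data, and any expectation is loose. Among the measured compounds shown here, a small downward step is expected, possibly none beyond the scatter, judged against the one available reading, compound 1 at 100%, which leaves no room upward. For compound 4 the expected value is 85%, with an estimated range of 60% to 100%.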

Compound 4, percent of the compound remaining: 97%
The estimate for compound 4 lay 12 percentage points below the measured number; the measured number falls inside the stated range.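

Within the data shown here, compound 3 carries no single number in this assay and compound 4 gives 97% there, so no step between them can be read. Going by these compounds, whether 2-fluorobenzyl in place of 3-chloro-2-fluorophenyl shifts the percent remaining stays open, and no supporting evidence bears on the result.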